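Carboxy in place of hydroxymethyl: expecting a drop in lipophilicity

This account rests on a few compounds, and the source may have more. Where it says the series, first, only, none or still open, it means among the compounds named here.

Measured so far:
compound 1 `CCc1ccc(N(CC(C)C)S(=O)(=O)c2ccc3cc(OCC4CCOCC4)c(CO)cc3c2)cc1` gives 5.1
compound 2 `CC(C)CN(c1ccc(C(C)(C)C)cc1)S(=O)(=O)c1ccc2c(c1)C(=O)CC(C1CCOCC1)O2` gives 4.97
compound 3 `CCc1ccc(N(CC(C)C)S(=O)(=O)c2ccc3c(c2)C(=O)C[C@H](C2CCOCC2)O3)cc1` gives 4.24

These three compounds were tested in a physicochemical assay for lipophilicity, at pH 7.4; a higher number here means a more lipophilic compound, a lower number a more polar compound. Compound 1 sits at the top of the three numbers, but the number for compound 2 lies within the usual scatter of it, so the two cannot be told apart. Compound 3 lies clearly lower, beyond the scatter, on a different core.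

The step considered here goes from compound 1 to compound 4 `CCc1ccc(N(CC(C)C)S(=O)(=O)c2ccc3cc(OCC4CCOCC4)c(C(=O)O)cc3c2)cc1`, which has not yet been measured. The change is carboxy in place of hydroxymethyl on an aromatic carbon. Among the compounds with values here, no pair of measured compounds shows this change, so the size of its effect cannot be read off the data. An exchange of this kind, a hydroxymethyl against a carboxy group, is generally expected to make a compound markedly less lipophilic at this pH, so a downward step well beyond the scatter is anticipated. The expected step is a number 2.40 log units lower from compound 1 to compound 4 (beyond the scatter). For compound 4 the estimate in this assay is 2.7, with a range from 1.8 to 3.6.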

Compound 4, distribution coefficient: 1.77
Compound 4: the middle estimate sits 0.93 log units above what was measured; the whole stated range lies above it.
By their numbers in this assay, from the lowest: compound 4; then compound 3; then compounds 2 and 1 (each within the scatter of the next).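

Within the data shown here, compound 1 and compound 4 form the first measured pair here that differs in only one place, so the effect of a change on this aromatic carbon, ortho to a (oxan-4-yl)methoxy group, can now be read directly. In this assay, carboxy in place of hydroxymethyl gives a number 3.33 log units lower from compound 1 to compound 4 (beyond the scatter), which shows that this single exchange, with the rest of the molecule held constant, can move the number far beyond the scatter. Nothing available explains the size of this step.

The compounds shown leave open where a methyl ester, a primary amide or an aminomethyl group at this same position would fall in this assay. They also leave open whether the same exchange would give a step of similar size on the core of compound 3, or at another position on the shared core.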